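Thiazolyl replacement for the phenyl in compound 2

The source may report more compounds than this note shows. Statements on the series, on what has been measured and on what is new or still open speak of the compounds shown alone.

Three compounds of this series have numbers in an assay on isolated protein for inhibition of acid ceramidase (Homo sapiens), read by LC-MS, with a stated time of 1 h; a higher number here means a weaker inhibitor, a lower number a stronger inhibitor. Compound 1 `Cc1oc(=O)n(C(=O)NCCCCc2ccccc2)c1-c1ccccc1` gives 42 nM. Compound 2 `O=C(NCCCCc1ccccc1)n1cc(-c2ccccc2)oc1=O` gives 90 nM, the second highest of the three numbers, with compound 3 nearest and compound 1 furthest from it. Compound 3 `O=C(NCCCCc1ccccc1)n1cc(-c2ccc(F)cc2)oc1=O` gives 185 nM.

Within the data shown here, the only step between compounds that differ in one place is a 2.1-fold higher number from compound 2 to compound 3 (0.31 log units; beyond the scatter), a modest weakening on putting fluoro in place of hydrogen on the phenyl.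

Compound 4 `O=C(NCCCCc1ccccc1)n1cc(-c2nccs2)oc1=O` is not yet measured. It is reached from compound 2 by the change (1,3-thiazol-2-yl in place of phenyl on an aromatic carbon). Among the measured compounds shown here, no measured step exchanges the whole aryl ring, so the one step that bears on this change does so only loosely: in this assay a change on the same phenyl gave a 2.1-fold higher number from compound 2 to compound 3 (0.31 log units; beyond the scatter), a modest move toward weaker inhibition, and nothing shows a gain from altering that ring.

The expectation for compound 4 in this assay is therefore a modest weakening, a 1.8-fold higher number from compound 2 to compound 4 (0.25 log units; within the scatter), with wide uncertainty since the ring itself is exchanged. Compound 4 is estimated at 160 nM, between 50 nM and 500 nM.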

Compound 4, half-maximal inhibitory concentration: 59 nM
Compound 4: middle estimate off by 2.7-fold (0.43 log units), on the high side; the range from low to high includes it.
By their numbers in this assay, from the lowest: compounds 1, 4 and 2 (each within the scatter of the next, the first and the last beyond it); then compound 3.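

In this assay the position on the shared core tolerates exchange of the whole aryl ring: a 1.5-fold lower number from compound 2 to compound 4 (0.18 log units; within the scatter) leaves the two compounds indistinguishable, although a six-membered aromatic ring of carbon only gives way to a five-membered aromatic ring with 2 hetero atoms. The earlier compounds shown here showed only a substitution on the phenyl at this place, whereas a 3.1-fold lower number from compound 3 to compound 4 (0.50 log units; beyond the scatter) now shows that the 1,3-thiazol-2-yl and 4-fluorophenyl groups can be separated beyond the scatter, in favour of the 1,3-thiazol-2-yl group. The series therefore no longer reads as one in which every alteration of this ring costs inhibition, although the gain holds only against the 4-fluorophenyl group and not against the plain phenyl, and no measurement at hand accounts for either result.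

Still open, on these data alone, is how far this tolerance extends, for instance to a pyridin-2-yl or an oxazol-2-yl ring at the same place, or to a 1,3-thiazol-2-yl ring carrying a methyl or an amine. Also open, as far as these compounds go, is whether the 1,3-thiazol-2-yl group keeps its standing when the core carries the extra methyl of compound 1.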